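This account rests on a few compounds, and the source may have more. Where it says the series, first, only, none or still open, it means among the compounds named here.

Measured compounds in an ADME assay on THP-1 cells (Homo sapiens) for cytotoxicity, read by flow cytometry and propidium iodide staining, with a stated time of 72 h; a higher number here means a weaker inhibitor, a lower number a stronger inhibitor:

- compound 1 `COc1cccc(-c2cc(=O)c3cc(NC(C)=O)ccc3o2)c1`: 10000 nM
- compound 2 `COc1cccc(-c2oc3ccc(NC(C)=O)cc3c(=O)c2OC)c1`: 5000 nM
- compound 3 `COc1c(-c2ccccc2)oc2ccc(N)cc2c1=O`: 74000 nM

In this assay compound 1 gives 10000 nM and compound 2 gives 5000 nM. The change between them is methoxy in place of hydrogen on an aromatic carbon and it made the step of a 2.0-fold lower number from compound 1 to compound 2 (0.30 log units; within the scatter). Compound 3 gives 74000 nM, the highest of the three numbers; how its core differs from the core of compound 1 is not broken down here.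

Compound 4 `COc1ccc(-c2oc3ccc(N)cc3c(=O)c2OC)cc1` has not yet been measured. It differs from compound 3 by methoxy in place of hydrogen on an aromatic carbon. Within the data shown here, this is the same kind of change as the one from compound 1 to compound 2, but not the same: there the methoxy entered on an aromatic carbon of a six-membered aromatic ring with 1 oxygen, part of a fused or bridged system of two rings, ortho to a 3-methoxyphenyl group and ortho to a group of 1 heavy atom, two atoms from the ring oxygen; here it enters on a six-membered aromatic ring of carbon only, para to a large group.

Since the earlier step of a 2.0-fold lower number from compound 1 to compound 2 (0.30 log units; within the scatter) stayed within the scatter, a step of similar size is expected from compound 3 to compound 4, about a 1.5-fold lower number from compound 3 to compound 4 (0.17 log units; within the scatter). Compound 4 is therefore estimated at 50000 nM in this assay, with a range from 20000 nM to 150000 nM expected.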

Compound 4, half-maximal inhibitory concentration: 21000 nM
Estimate against measurement, compound 4: 2.4-fold (0.38 log units) above; the measured number falls inside the stated range.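

In this assay, methoxy in place of hydrogen on an aromatic carbon, here on a six-membered aromatic ring of carbon only and para to a large group, gives a 3.5-fold lower number from compound 3 to compound 4 (0.55 log units; beyond the scatter), a modest step. Both steps with this change point the same way, although only the new one lies beyond the scatter, and their sizes cannot be told apart, so the change carries over from one core to the other as far as these two pairs can show: the same change on two cores in this assay, a 2.0-fold lower number (0.30 log units; within the scatter) from compound 1 to compound 2 and a 3.5-fold lower number (0.55 log units; beyond the scatter) from compound 3 to compound 4, 1.8-fold (0.25 log units) apart, within the scatter of two such steps. This does not show a fixed step for the change on other cores, and with the methoxy entering at a different place in each pair and the cores also differing, the two pairs cannot separate an effect of the place from an effect of the core.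

What the compounds shown leave open is whether the step at this place on the ring of carbon only depends on methoxy itself. A longer chain such as ethoxy, a halogen such as chlorine, or a carboxylic acid entering at the same place could give a step of similar size, a larger one or one in the opposite direction.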